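This account rests on a few compounds, and the source may have more. Where it says the series, first, only, none or still open, it means among the compounds named here.

Measured so far in an ADME assay on Karpas-1106P cells (Homo sapiens) for cytotoxicity; a higher number here means that more compound is needed for the effect, a lower number that less compound is needed:
compound 1 `Cc1ccc(S(=O)(=O)N[C@@H](CC(=O)NC(C)(C)C)C(=O)NCCNC(=O)c2cc(Cl)ccn2)cc1` — > 11100 nM
compound 2 `COc1cc(OC)cc(C(=O)NCCNC(=O)[C@H](CC(=O)NC(C)(C)C)NS(=O)(=O)c2ccc(C)cc2)c1` — > 11100 nM

In this assay compound 1 gives > 11100 nM, which is a limit of the assay rather than a number. In this assay compound 2 gives > 11100 nM, again only a limit. The evidence available is the limit of > 11100 nM in this assay, at which 2 of the 2 values shown sit, so the step that the two limits leave unreadable from compound 1 to compound 2 cannot be read in either size or direction. Compound 2 therefore stands at the limit, with no number to set it against.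

Compound 3 `Cc1ccc(S(=O)(=O)N[C@@H](CC(=O)NC(C)(C)C)C(=O)NCCNC(=O)c2cc(C)ccn2)cc1` differs from compound 2 by 4-methylpyridin-2-yl in place of 3,5-dimethoxyphenyl on a carbonyl carbon. Among the compounds with values here, the single measured step, a step that the two limits leave unreadable from compound 1 to compound 2, gives no readable size, so nothing can be taken from it; compound 1 carries a 4-chloropyridin-2-yl group on the same carbonyl carbon and also sits at the limit. Compound 3 is expected to remain at or near the limit, with the step that the limit leaves unreadable from compound 2 to compound 3 expected to stay within the scatter. Compound 3 is estimated at 20000 nM, within 8000 nM to 60000 nM.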

Compound 3, half-maximal effective concentration: > 11100 nM
Compound 3 was reported as a limit; the forecaster's own chance of this, stated with the estimate: 80%; the middle value is on the limit's open side.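

Within the data shown here, compound 1, compound 2 and compound 3 all sit at a limit of this assay, not at a number, so no step among them can be read: the limit of > 11100 nM in this assay, at which 3 of the 3 values shown sit.

The compounds shown leave open what the actual values are, and whether any group on this carbonyl carbon gives a readable number.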